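Three Amides at the Limit and a Fourth to Come

A few compounds are considered here, and "the series" means these few. Any claim that something is new, unique, unknown or untested is made for them only; others in the source may bear on it.

Compound 1 `Cc1nnc(Sc2cc(NC(=O)c3ccc(Cl)cc3)c3ccccc3c2O)s1` gives, in a functional assay on HCT-116 cells (Homo sapiens) for antiproliferative activity, read by MTT assay, with a stated time of 48 h (a lower number here means a stronger inhibitor, a higher number a weaker inhibitor), a value of > 100000 nM, which is a limit of the assay and not a number.
Compound 2 `O=C(Nc1cc(Sc2ncn[nH]2)c(O)c2ccccc12)c1ccc2ccccc2c1` gives in this assay the value > 100000 nM, again a limit of the assay.
Compound 3 `O=C(Nc1cc(Sc2nncs2)c(O)c2ccccc12)c1ccc(Cl)cc1` gives in this assay the value > 100000 nM, also a limit of the assay.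

Compound 2 thus stands at the limit of this assay, the same place where every value shown sits (the limit of > 100000 nM in this assay, at which 3 of the 3 values shown sit); only a limit is known for it, and the same holds for the two other values shown. Among the compounds with values here, the one measured step between neighbours, a step that the two limits leave unreadable from compound 1 to compound 3, is hydrogen in place of methyl on an aromatic carbon, and the two limits leave its size unreadable. Within the data shown here, compound 4 `COc1cccc(C(=O)Nc2cc(Sc3ncn[nH]3)c(O)c3ccccc23)c1` differs from compound 2 by 3-methoxyphenyl in place of naphthalen-2-yl on a carbonyl carbon, a change at the carbonyl carbon that no measured step touches, so no measured step bears on it. With three limits and one unreadable step, nothing points in either direction, and no movement beyond the scatter is expected, the estimated step being a number no higher from compound 2 to compound 4 (the limit leaves the size open). Compound 4 is therefore expected to give 100000 nM in this assay, within an estimated range from 30000 nM to 300000 nM, most likely again reported only as a limit.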

Compound 4, half-maximal inhibitory concentration: > 100000 nM
Compound 4: only a limit was reported; the forecaster's own chance of this, stated with the estimate: 75%; the middle value lies on the limit itself.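

In this assay compound 4, like compound 2, gives only a limit, so no step can be read from compound 2 to compound 4: the limit of > 100000 nM in this assay, at which 4 of the 4 values shown sit.

The compounds shown leave open whether any change to the shared core or its amide group would bring a value that is a number and not a limit.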